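This account rests on a few compounds, and the source may have more. Where it says the series, first, only, none or still open, it means among the compounds named here.

Compound 2 `Nc1scc(CN2CCN(c3ccccc3C(F)(F)F)CC2)c1C(=O)c1ccc(Cl)cc1` gives -7.5% in a functional assay on CHO cells with adenosine receptor A1 (Homo sapiens) as the target, read by cAMP accumulation and immunoassay, with a stated time of 6 min, tested at 0.1 uM; a lower number here means a stronger effect, a higher number a weaker effect of the compound at the concentration tested. Of the two numbers measured, compound 2 stands at the low end, but its nearest neighbour, compound 1 `Nc1scc(CN2CCN(c3ccc(F)cc3Cl)CC2)c1C(=O)c1ccc(Cl)cc1`, gives -6.2% in this assay, and the gap between them is within the scatter. For the measured compounds named here, the only measured step, a number 1.3 percentage points lower from compound 1 to compound 2 (within the scatter), therefore moved the read-out by an amount no larger than repeat measurements usually differ.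

Compound 3 `Nc1scc(CN2CCN(c3ccc(OC(F)(F)F)cc3)CC2)c1C(=O)c1ccc(Cl)cc1` has not yet been measured. It differs from compound 2 by 4-(trifluoromethoxy)phenyl in place of 2-(trifluoromethyl)phenyl on an amine nitrogen in a ring. Going by the values given here, the one step that bears on this change, a number 1.3 percentage points lower from compound 1 to compound 2 (within the scatter), also exchanged the aryl group on the ring nitrogen and stayed within the scatter, so no step beyond the scatter is expected in this assay in either direction. Compound 3 is therefore expected to give -7%, with a range of -18% to 4%. The expected step is a number 0.5 percentage points higher from compound 2 to compound 3 (within the scatter), which is estimated to lie within the scatter.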

Compound 3, a percentage reported as activity, at one concentration (the size of the read-out at that concentration, not a potency): -13%
The estimate for compound 3 lay 6 percentage points above the measured number; the measured number falls inside the stated range.
By their numbers in this assay, from the lowest: compounds 3, 2 and 1 (each within the scatter of the next).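

The exchange of 2-(trifluoromethyl)phenyl for 4-(trifluoromethoxy)phenyl on the amine nitrogen in a ring brings in an oxygen and a hydrogen-bond acceptor, yet this assay shows a number 5.5 percentage points lower from compound 2 to compound 3 (within the scatter), and the exchange of 2-chloro-4-fluorophenyl for the same group shows a number 6.8 percentage points lower from compound 1 to compound 3 (within the scatter). With all the printed steps inside the scatter, none of these three aryl groups at this position can be told apart from the others in this assay, even with the new group carrying its substituent at a different ring position. No measurement available here accounts for this result.

Going by these compounds, whether an amine, a carboxylic acid or a plain alkyl chain at this position would move the read-out beyond the scatter remains open. A read-out at one concentration also leaves open whether these compounds differ in potency.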